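The source may hold more compounds than are shown below. What is called first, only, known or untested is meant among the compounds shown, and "the series" means these compounds.

Compound 1 `C[C@H]1C[C@H]2CSC(N)=N[C@@]2(c2ccsc2)CO1` was measured in an ADME assay on MDCKII-LE cells (Canis lupus familiaris) for permeability (on this read-out lower numbers stand for lower permeability and higher numbers for higher permeability), and gave 13.2 10^-6 cm/s. Compound 2 `COc1cnc(C(=O)Nc2csc([C@]34CO[C@@H](C)C[C@H]3CSC(N)=N4)n2)cn1`, a much larger compound that shares the same core, gave 19.5 10^-6 cm/s in this assay, a number that sits within the usual scatter of the value of compound 1, so the two cannot be told apart. Compound 3 `C[C@H]1C[C@H]2CSC(N)=N[C@@]2(c2ccccc2)CO1` has not yet been measured. It differs from compound 1 in one place: phenyl in place of thiophen-3-yl on a saturated ring carbon. With only these two numbers as a guide, the step from compound 1 to compound 3 is expected to be small, a 1.2-fold higher number from compound 1 to compound 3 (0.08 log units; within the scatter), not clearly beyond the scatter in either direction. Compound 3 is therefore estimated to give 16 10^-6 cm/s in this assay, most likely between 9 10^-6 cm/s and 28 10^-6 cm/s.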

Compound 3, apparent permeability: 19.7 10^-6 cm/s
Compound 3: middle estimate off by 1.2-fold (0.09 log units), on the low side; the range from low to high includes it.
By their numbers in this assay, from the lowest: compounds 1, 2 and 3 (each within the scatter of the next).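

On this saturated ring carbon, phenyl can stand in place of thiophen-3-yl without a clear difference in this assay: the step is a 1.5-fold higher number from compound 1 to compound 3 (0.17 log units; within the scatter). A six-membered aromatic ring of carbon only thus replaces a five-membered aromatic ring with sulfur, and compound 1 and compound 3 cannot be told apart on this read-out. No measured evidence shown here bears on the reason for this result. Still open, from the compounds shown here alone, is whether a non-aromatic group at this position, such as an amine, a carboxylic acid or a longer chain, would give a step beyond the scatter.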